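A Methoxy-to-Chloro Swap Carried Onto a Second Core

The source may hold more compounds than are shown below. What is called first, only, known or untested is meant among the compounds shown, and "the series" means these compounds.

Three compounds have been measured in a functional assay on the whole organism (Abdomen, strain Swiss albino) with Mus musculus as the target, with stated times of 10 min and 5 min, at a dose of 15 mg/kg by the oral route; on this read-out higher numbers stand for a stronger effect at the one dose given and lower numbers for a weaker effect:

Compound 1 `CCOC(=O)c1onc(-c2cn(-c3ccccc3)nc2-c2ccc(OC)cc2)c1C(=O)OCC` gives 11.4%
Compound 2 `CCOC(=O)c1onc(-c2cn(-c3ccccc3)nc2-c2ccc(Cl)cc2)c1C(=O)OCC` gives 17.3%
Compound 3 `COc1ccc(-c2nn(-c3ccccc3)cc2-c2cc(-c3ccccc3)on2)cc1` gives 11.8%

Compounds 1 and 2 share one core and differ in a single spot: chloro in place of methoxy on an aromatic carbon. That swap gave a number 5.9 percentage points higher from compound 1 to compound 2 (within the scatter), so the two numbers cannot be told apart. Compound 3 carries a different core; how its core differs from that of compound 1 is not broken down here. Its value in this assay sits close to that of compound 1 and to that of compound 2, all within the scatter.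

Compound 4 `Clc1ccc(-c2nn(-c3ccccc3)cc2-c2cc(-c3ccccc3)on2)cc1` has not yet been measured. It stands to compound 3 as compound 2 stands to compound 1: chloro in place of methoxy on an aromatic carbon. The place of the change reads the same in both pairs, so this is the same change made on another core. Among the compounds with values here, because the measured step of a number 5.9 percentage points higher from compound 1 to compound 2 (within the scatter) stayed within the scatter, the expected step of a number 5.2 percentage points higher from compound 3 to compound 4 (within the scatter) is small and of about that size, resting on the single earlier pair alone. Compound 4 is thus expected to give 17% in this assay, somewhere between 8% and 27%.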

Compound 4, a percentage reported as activity, at one dose (the size of the read-out at that dose, not a potency): 1.58%
The estimate for compound 4 lay 15.4 percentage points above the measured number; measured number below the stated range.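

In this assay, putting chloro in place of methoxy on the second core gave a number 10.2 percentage points lower from compound 3 to compound 4 (beyond the scatter), so the small rise seen on the first core did not carry over. The two cores clearly answer this swap differently: the same change on two cores in this assay, a number 5.9 percentage points higher (within the scatter) from compound 1 to compound 2 and a number 10.2 percentage points lower (beyond the scatter) from compound 3 to compound 4, 16.1 percentage points apart, beyond the scatter of two such steps This shows that, in this series, a step read on one core is a poor guide to the same step on the other, but it does not show why, and a single pair on each core cannot say which feature of the cores matters or how any further core would respond.

The compounds shown leave open which part of the difference between the two cores goes with the change in outcome. They also offer only methoxy and chloro at this place, so whether another group there, such as an amine, a carboxylic acid or a longer chain, would likewise behave differently on the two cores remains an open question.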